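The compounds below may be only part of what the source reports. "The series", "measured", "known", "first", "only" and "open" are said of these compounds alone.

In a functional assay on A-375 cells (Homo sapiens) for antiproliferative activity (a lower number here means a stronger inhibitor, a higher number a weaker inhibitor), three compounds sharing one core have been measured. Compound 1 `CCCCO/N=C/c1c(N)ncnc1Oc1ccc2[nH]c(C)cc2c1F` gives 446 nM, compound 2 `Cc1cc2c(F)c(Oc3ncnc(N)c3/C=N/OCc3ccccc3)ccc2[nH]1` gives 62 nM, and compound 3 `Cc1cc2c(F)c(Oc3ncnc(N)c3/C=N/OCCCO)ccc2[nH]1` gives 336 nM. Compound 3 thus stands second highest of the three numbers: it lies within the scatter of compound 1, as a 1.3-fold lower number from compound 1 to compound 3 (0.12 log units; within the scatter) shows, while compound 2 stands clearly apart, with a 5.4-fold higher number from compound 2 to compound 3 (0.73 log units; beyond the scatter). The large shift seen in a 7.2-fold lower number from compound 1 to compound 2 (0.86 log units; beyond the scatter) concerns the phenyl end of the chain and does not bear directly on the present question.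

Compound 4 `CCO/N=C/c1c(N)ncnc1Oc1ccc2[nH]c(C)cc2c1F` is not yet measured. It differs from compound 3 by hydrogen in place of hydroxymethyl on a saturated chain carbon, two bonds along the chain from an oxygen, which cuts the chain back and removes the hydroxy end. Going by the values given here, the only step that speaks to such a change at this end of the chain is a 1.3-fold lower number from compound 1 to compound 3 (0.12 log units; within the scatter), which swapped hydroxy for methyl there and stayed within the scatter. Nothing measured shows that shortening the chain by one carbon matters, but nothing shows that it does not either. The step is therefore expected to be small, a 1.3-fold higher number from compound 3 to compound 4 (0.10 log units; within the scatter), with a slight lean toward a higher number, and compound 4 is estimated at 420 nM in this assay, within a range from 150 nM to 1200 nM.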

Compound 4, half-maximal inhibitory concentration: 27 nM
Estimate against measurement, compound 4: 16-fold (1.19 log units) above, outside the stated range (below it).
By their numbers in this assay, from the lowest: compound 4; then compound 2; then compounds 3 and 1 (each within the scatter of the next).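

Cutting the chain back at this position turns out to matter far more than changing its end: in this assay the replacement of hydroxymethyl by hydrogen gives a 12-fold lower number from compound 3 to compound 4 (1.09 log units; beyond the scatter), and the replacement of ethyl by hydrogen, with no hydroxy group on either side, gives a 17-fold lower number from compound 1 to compound 4 (1.22 log units; beyond the scatter), whereas the earlier swap of hydroxy for methyl at the chain end had stayed within the scatter. The short chain also outdoes the phenyl-bearing chain, with a 2.3-fold lower number from compound 2 to compound 4 (0.36 log units; beyond the scatter), which makes compound 4 the strongest of the four, but chain length alone does not order the series, as compound 2 carries the bulkier group and still has a lower number than compound 1 and compound 3. No measurement available here explains why the shorter chain gives so much lower a number.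

The compounds shown leave open whether a methoxy group would go lower still or whether the ethoxy chain is already near the best length at this position. They also leave open whether a 2-hydroxyethoxy chain, or an ethoxy chain ending in an amine or a carboxylic acid, would keep the low number of compound 4.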